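The source may report more compounds than this note shows. Statements on the series, on what has been measured and on what is new or still open speak of the compounds shown alone.

In a functional assay on HeLa cells (Homo sapiens) for inhibition, read by MTT assay, with a stated time of 72 h (on this read-out lower numbers stand for stronger inhibition and higher numbers for weaker inhibition), compound 3 `C=C(Br)C(=O)Nc1cccc(/C=C/C(=O)Nc2cc(OC)c(OC)c(OC)c2)c1` gives 880 nM, the lowest of the three numbers, compared with compound 2 `COc1cc(NC(=O)/C=C/c2cccc(OCc3ccccc3)c2)cc(OC)c1OC` at 2200 nM and compound 1 `COc1cccc(/C=C/C(=O)Nc2cc(OC)c(OC)c(OC)c2)c1` at 16500 nM. Compound 4 `COc1cc(NC(=O)/C=C/c2cccc(N)c2)cc(OC)c1OC` is not yet measured. It has hydrogen in place of (1-bromoethenyl)carbonyl on a nitrogen on an aromatic ring. Among the measured compounds shown here, two measured steps bear on this change: the large 19-fold lower number from compound 1 to compound 3 (1.27 log units; beyond the scatter) and the modest 2.5-fold lower number from compound 2 to compound 3 (0.40 log units; beyond the scatter). Both introduce the ((1-bromoethenyl)carbonyl)amino group, although neither starts from amino, so they guide the estimate only indirectly. A large rise is therefore expected in this assay, with the estimated change being an 11-fold higher number from compound 3 to compound 4 (1.06 log units; beyond the scatter). Compound 4 is estimated at 10000 nM, within an expected range of 2500 nM to 40000 nM.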

Compound 4, half-maximal inhibitory concentration: 53100 nM
Compound 4: middle estimate off by 5.3-fold (0.73 log units), on the low side, and the stated range ends below it.
By their numbers in this assay, from the lowest: compound 3; then compound 2; then compound 1; then compound 4.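

In this assay, removing the (1-bromoethenyl)carbonyl from this nitrogen gives a 60-fold higher number from compound 3 to compound 4 (1.78 log units; beyond the scatter), so the gain in compound 3 depends on that group and not on the nitrogen alone. Amino also falls behind both ethers at this aromatic carbon, with a 24-fold higher number from compound 2 to compound 4 (1.38 log units; beyond the scatter) against benzyloxy and a 3.2-fold higher number from compound 1 to compound 4 (0.51 log units; beyond the scatter) against methoxy. The free amine therefore has the highest number of the four compounds.

A simple acetyl group on this nitrogen would begin to separate the part of the carbonyl from that of the bromine and the double bond. No measurement shown explains the size of these steps.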